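A few compounds are considered here, and "the series" means these few. Any claim that something is new, unique, unknown or untested is made for them only; others in the source may bear on it.

The three measured compounds share one core and differ only in the aryl group on an aromatic nitrogen. Compound 1 `CCc1ccccc1-n1nncc1CN1C(=O)C2(C(C#N)=C(N)Oc3c(N)cc4nc5ccccc5nc4c32)c2ccccc21` carries a 2-ethylphenyl there, and in a functional assay on A549 cells (Homo sapiens) for antiproliferative activity, read by MTT assay, with a stated time of 48 h (on this read-out lower numbers stand for stronger inhibition and higher numbers for weaker inhibition), compound 1 gives 24600 nM. Compound 2 `Cc1ccc(-n2nncc2CN2C(=O)C3(C(C#N)=C(N)Oc4c(N)cc5nc6ccccc6nc5c43)c3ccccc32)cc1C` carries a 3,4-dimethylphenyl in that place; in this assay compound 2 reaches only > 50000 nM, which is a limit of the assay and not a number. Compound 3 `Cc1ccc(Cl)cc1-n1nncc1CN1C(=O)C2(C(C#N)=C(N)Oc3c(N)cc4nc5ccccc5nc4c32)c2ccccc21` carries a 5-chloro-2-methylphenyl in the same place; in this assay compound 3 likewise sits at > 50000 nM, again a limit rather than a number. Thus an at least 2.0-fold higher number from compound 1 to compound 2 (0.30 log units; that floor lies within the scatter) and an at least 2.0-fold higher number from compound 1 to compound 3 (0.30 log units; that floor lies within the scatter), while a step that the two limits leave unreadable from compound 2 to compound 3. Two of the three values rest on (the limit of > 50000 nM in this assay, at which 2 of the 3 values shown sit).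

Compound 4 `N#CC1=C(N)Oc2c(N)cc3nc4ccccc4nc3c2C12C(=O)N(Cc1cnnn1-c1c(Cl)cc(Cl)cc1Cl)c1ccccc12` has not yet been measured. It differs from compound 3 by 2,4,6-trichlorophenyl in place of 5-chloro-2-methylphenyl on an aromatic nitrogen. Going by the values given here, the only steps that bear on this position are the two just named, each carrying compound 1 to the limit, and the step between compound 2 and compound 3 cannot be read. Compound 4 is therefore expected to remain at or beyond the limit, with a step that the limit leaves unreadable from compound 3 to compound 4 estimated as no readable change. The estimate for compound 4 in this assay is 60000 nM, with a range from 25000 nM to 150000 nM.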

Compound 4, half-maximal inhibitory concentration: > 50000 nM
Compound 4 ended at the assay's limit (the forecaster's own chance of this, stated with the estimate: 70%); the middle value does not contradict the limit.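

Swapping the 5-chloro-2-methylphenyl for a 2,4,6-trichlorophenyl on this aromatic nitrogen removes the methyl group and leaves an aryl ring carrying chlorine alone, yet in this assay this ring gives no number either, so a third aryl group joins the two that stop at the limit and compound 1 remains the only one of the four with a measured value. Against the 2-ethylphenyl, the new group gives an at least 2.0-fold higher number from compound 1 to compound 4 (0.30 log units; that floor lies within the scatter), and as that floor lies within the scatter, compound 1 cannot be called more active than compound 4 on this evidence. The steps to compound 4 from compound 2 and from compound 3 cannot be read, because both ends of each step rest on the same limit: the limit of > 50000 nM in this assay, at which 3 of the 4 values shown sit.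

The compounds shown leave open how far beyond the limit compound 2, compound 3 and compound 4 lie, so no order can be set among these three aryl groups. They also leave open whether a phenyl ring bearing an amine or a carboxylic acid, or a longer alkyl chain in place of the aryl group, would give a value clear of the limit in this assay.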